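Cytotoxicity notes on three measured compounds and one pending

The compounds below may be only part of what the source reports. "The series", "measured", "known", "first", "only" and "open" are said of these compounds alone.

compound 1: `N#CC(C#N)Cc1nccs1`; in a functional assay on SH-SY5Y cells (Homo sapiens) for cytotoxicity, read by MTT assay, with a stated time of 48 h (a higher number here means a weaker inhibitor, a lower number a stronger inhibitor), compound 1 gives > 120000 nM, a limit of the assay
compound 2: `FC(F)=C(F)CCSc1nccs1`; in this assay compound 2 gives > 120000 nM, a limit of the assay
compound 3: `FC(F)=C(F)CCSc1ncc(-c2ccncc2)s1`; in this assay compound 3 gives > 120000 nM, a limit of the assay

Compound 3 therefore stands only at the limit, and every value in hand sits there too (the limit of > 120000 nM in this assay, at which 3 of the 3 values shown sit). Going by the values given here, the one single-site step among the measured compounds, a step that the two limits leave unreadable from compound 2 to compound 3, cannot be read because both ends are limits.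

Compound 4 is `FC(F)=C(F)CCSc1ncc(Cl)s1`. Its change from compound 3 is chloro in place of pyridin-4-yl on an aromatic carbon. Among the compounds with values here, no measured step reads on this change, so no direction can be drawn from the series; the only expectation is that compound 4 also stays at the limit.

Compound 4 is estimated at 150000 nM, with a range from 60000 nM to 500000 nM. The expected step is a step that the limit leaves unreadable from compound 3 to compound 4, which amounts to no change beyond the scatter.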

Compound 4, half-maximal inhibitory concentration: > 120000 nM
Compound 4: no number, only a limit (the forecaster's own chance of this, stated with the estimate: 85%); the middle value lies beyond the limit too.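

No step can be read from compound 2 or compound 3 to compound 4, since both ends of each pair are limits: the limit of > 120000 nM in this assay, at which 4 of the 4 values shown sit. The compounds shown leave open which structural change, if any, would give a readable value in this assay.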